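The compounds below may be only part of what the source reports. "The series", "measured", "known", "first", "only" and "open" are said of these compounds alone.

Measured compounds:
- compound 1, `O=C(/C(=C\c1ccccc1OCc1ccccc1)SCc1ccc(F)cc1)c1ccc(Cl)cc1`: 1000 nM
- compound 2, `Cc1ccc(CS(=O)(=O)/C(=C/c2ccccc2OCc2ccccc2)C(=O)c2ccc(Cl)cc2)cc1`: 1000 nM

Both values come from a functional assay on DU-145 cells (Homo sapiens) for inhibition, read by trypan blue exclusion, with a stated time of 96 h; on this read-out lower numbers stand for stronger inhibition of growth and higher numbers for weaker inhibition of growth. Going by the values given here, the one step between the measured compounds, no change at the digits printed from compound 1 to compound 2 (within the scatter), swaps the sulfur-linked group on the chain carbon without shifting the read-out beyond the scatter. Compound 2 therefore stands level with compound 1 at the digits recorded; nothing in the pair separates them.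

The next compound, compound 3, `O=C(/C(=C\c1ccccc1OCc1ccccc1)SCc1ccc(Cl)c(Cl)c1)c1ccc(Cl)cc1`, is to be measured in this assay. It differs from compound 2 by (3,4-dichlorobenzyl)sulfanyl in place of (4-methylbenzyl)sulfonyl on a double-bonded chain carbon bound to a carbonyl carbon and a double-bonded chain carbon. Among the compounds with values here, the only step that bears on this change is no change at the digits printed from compound 1 to compound 2 (within the scatter), which showed no movement; it covered a change at the same place, from a sulfanyl to a sulfonyl group together with a change of the ring substituent, and the reverse sense of that change plus a different halogen pattern has no other measured precedent here. The expectation is a step of no change at the digits printed from compound 2 to compound 3 (within the scatter), that is, none beyond the scatter, resting on the flat step no change at the digits printed from compound 1 to compound 2 (within the scatter). Compound 3 is estimated at 1000 nM, with a range from 300 nM to 3000 nM.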

Compound 3, concentration for 50% growth inhibition: 10000 nM
For compound 3 the middle estimate is 10-fold (1.00 log units) below the measured one, and the stated range ends below it.
By their numbers in this assay, from the lowest: compounds 1 and 2 (each within the scatter of the next); then compound 3.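

In this assay, the group on the double-bonded chain carbon bound to a carbonyl carbon and a double-bonded chain carbon now proves able to move the read-out, with a 10-fold higher number from compound 2 to compound 3 (1.00 log units; beyond the scatter) and a 10-fold higher number from compound 1 to compound 3 (1.00 log units; beyond the scatter). The second of these steps keeps the sulfanyl link and replaces only 4-fluorophenyl with 3,4-dichlorophenyl, so this ring change alone is enough to weaken growth inhibition, and compound 3 is the weakest of the three, whereas the earlier change of both link and ring gave no change at the digits printed from compound 1 to compound 2 (within the scatter). No measurement on these compounds accounts for the loss seen with 3,4-dichlorophenyl.

The compounds shown leave open whether (3,4-dichlorobenzyl)sulfonyl would sit nearer compound 2 or compound 3, which would show whether the sulfonyl link can offset the ring change or the ring change dominates at either link. They also leave open how an unsubstituted benzyl group, or a carboxylic acid or an amine on that ring, would read in this assay, and so whether the response at this ring extends beyond the halogen and methyl groups seen here.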